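Shortening a Chain in Two Related Compounds

This account rests on a few compounds, and the source may have more. Where it says the series, first, only, none or still open, it means among the compounds named here.

Measured so far:
compound 1, `CCCc1cc(=O)n([C@@H]2O[C@H](COP(=O)(O)OP(=O)(O)OP(=O)(O)O)[C@@H](O)[C@H]2O)c(=O)[nH]1`: > 100000 nM
compound 2, `O=c1[nH]c(=O)n([C@@H]2O[C@H](COP(=O)(O)OP(=O)(O)O)[C@@H](O)[C@H]2O)cc1Br`: 7200 nM
compound 3, `CCCc1cc(=O)n([C@@H]2O[C@H](COP(=O)(O)OP(=O)(O)O)[C@@H](O)[C@H]2O)c(=O)[nH]1`: > 100000 nM

In an in vitro functional assay on 1321-N1 cells for agonist activity at P2Y purinoceptor 4 (Homo sapiens) (on this read-out higher numbers stand for an effect only at larger amounts of compound and lower numbers for an effect already at smaller amounts), compound 1 gives > 100000 nM, which is a limit of the assay rather than a number. Compound 3 gives > 100000 nM, again a limit. Compound 3 differs from compound 1 by a hydrogen atom in place of a group of 4 heavy atoms (3 oxygen, 1 phosphorus; no ring), on an oxygen. The step that the two limits leave unreadable from compound 1 to compound 3 cannot be read, because both values sit at the limit of > 100000 nM in this assay, at which 2 of the 3 values shown sit.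

Going by the values given here, compound 2 gives 7200 nM, the only number among the three. How the core of compound 2 differs from the core of compound 1 is not broken down here.

Compound 4, `O=c1[nH]c(=O)n([C@@H]2O[C@H](COP(=O)(O)O)[C@@H](O)[C@H]2O)cc1Br`, has not yet been measured in this assay. It differs from compound 2 by a hydrogen atom in place of a group of 4 heavy atoms (3 oxygen, 1 phosphorus; no ring), on an oxygen, the same change, at the same place, as that from compound 1 to compound 3. As the earlier step gave no readable size, the expected step of a 21-fold higher number from compound 2 to compound 4 (1.32 log units; beyond the scatter) rests only on compound 2 at 7200 nM and on the loss of the same group. Compound 4 is estimated at 150000 nM, between 30000 nM and 1000000 nM, with a fair chance that only a limit is reported.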

Compound 4, half-maximal effective concentration: > 100000 nM
Compound 4: no number, only a limit (the forecaster's own chance of this, stated with the estimate: 70%); the middle value does not contradict the limit.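

On the core of compound 2, putting a hydrogen atom in place of the group of 4 heavy atoms (3 oxygen, 1 phosphorus) on an oxygen gives an at least 13-fold higher number from compound 2 to compound 4 (1.14 log units; beyond the scatter) in this assay, so on this core the loss of that group goes with a large drop in effect. Compound 4 gives > 100000 nM, which is a limit and not a number, so the true size of the step may be larger than the one printed. The same change on the core of compound 1 cannot be read, and so nothing here shows whether the change has a similar size on both cores, because both of its values are limits too: the limit of > 100000 nM in this assay, at which 3 of the 4 values shown sit.

The compounds shown leave open whether a methyl group or an amine in place of that hydrogen would hold on to the effect of compound 2. Also open, from the compounds shown here alone, is whether any compound on the core of compound 1 reaches a readable number.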